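Chloro in Place of Methyl on the Fused Carbocyclic Ring

A few compounds are considered here, and "the series" means these few. Any claim that something is new, unique, unknown or untested is made for them only; others in the source may bear on it.

Compound 1 `CCn1c(CNc2ccccc2)nnc1SCc1nc2cc(C(=O)C(C)C)ccc2o1`: in an assay on isolated protein for inhibition of long-chain fatty acid transport protein 1 (Mus musculus) (a higher number here means a weaker inhibitor, a lower number a stronger inhibitor), compound 1 gives 520 nM.
Compound 2 `CCn1c(CNc2ccccc2)nnc1SCc1nc2cc(F)ccc2o1`: in this assay compound 2 gives 7800 nM.
Compound 3 `CCn1c(CNc2ccccc2)nnc1SCc1nc2cc(C)ccc2o1`: in this assay compound 3 gives only > 10000 nM, which is a limit of the assay and not a number.

Compound 3 thus stands at the weak end of the three values, sitting at the limit of > 10000 nM in this assay, at which 1 of the 3 values shown sits. Against compound 1 the two measured steps are large: a 15-fold higher number from compound 1 to compound 2 (1.18 log units; beyond the scatter) and an at least 19-fold higher number from compound 1 to compound 3 (1.28 log units; beyond the scatter). Between the two small substituents the step is an at least 1.2-fold higher number from compound 2 to compound 3 (0.10 log units; that floor lies within the scatter), a gap that lies within the scatter.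

Compound 4 `CCn1c(CNc2ccccc2)nnc1SCc1nc2cc(Cl)ccc2o1` differs from compound 3 by chloro in place of methyl on an aromatic carbon. The step that bears on this change is the one between fluoro and methyl at the same position, an at least 1.2-fold higher number from compound 2 to compound 3 (0.10 log units; that floor lies within the scatter), which showed no difference beyond the scatter. A change from methyl to chloro at the same position is therefore expected to give a step of an at least 1.1-fold lower number from compound 3 to compound 4 (0.04 log units; that floor lies within the scatter), with no movement beyond the scatter in either direction. Compound 4 is accordingly estimated at 9000 nM, with a range from 3000 nM to 30000 nM, and a fair chance that the assay again reports only a limit.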

Compound 4, half-maximal inhibitory concentration: 2300 nM
Beside the measured number, compound 4's estimate is 3.9-fold (0.59 log units) above it; measured number outside the range, below it.
By their numbers in this assay, from the lowest: compound 1; then compound 4; then compound 2. At a limit, above all of these: compound 3.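

In this assay, swapping one small substituent for another on this aromatic carbon can move the number beyond the scatter, which fluoro and methyl had not shown: chloro gives an at least 4.3-fold lower number from compound 3 to compound 4 (0.63 log units; beyond the scatter) and a 3.4-fold lower number from compound 2 to compound 4 (0.53 log units; beyond the scatter). Chloro does not close the gap to isopropylcarbonyl, however, with a 4.4-fold higher number from compound 1 to compound 4 (0.65 log units; beyond the scatter), so the ketone-bearing compound 1 keeps the lowest number of the series. Compound 3 remains a limit of the assay and not a number: the limit of > 10000 nM in this assay, at which 1 of the 4 values shown sits.

The compounds shown leave open whether bromo would lower the number further than chloro does. Going by these compounds, they also leave open whether acetyl or a carboxylic acid on the same carbon would come closer to isopropylcarbonyl, so what in that group accounts for its lead remains unknown.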